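Exchanging a Bromophenyl for a Difluorophenyl at the Limit

This account rests on a few compounds, and the source may have more. Where it says the series, first, only, none or still open, it means among the compounds named here.

Compound 1 `N#CC1=C(N)Oc2c(c3nc4ccccc4nc3c3ccccc23)C12C(=O)N(Cc1cnnn1-c1ccc(Br)cc1)c1ccccc12`: in an ADME assay on HUVEC cells (Homo sapiens) for antiproliferative activity, read by MTT assay, with a stated time of 48 h (on this read-out lower numbers stand for stronger inhibition and higher numbers for weaker inhibition), compound 1 gives > 50000 nM, which is a limit of the assay and not a number.
Compound 2 `N#CC1=C(N)Oc2c(c3nc4ccccc4nc3c3ccccc23)C12C(=O)N(Cc1cnnn1-c1ccc(S(N)(=O)=O)cc1)c1ccccc12`: in this assay compound 2 gives > 50000 nM, again a limit of the assay.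
Compound 3 `N#CC1=C(N)Oc2c(N)cc3nc4ccccc4nc3c2C12C(=O)N(Cc1cnnn1-c1cccc(Br)c1)c1ccccc12`: in this assay compound 3 gives > 50000 nM, also a limit of the assay.

Compound 3 therefore stands where every measured compound of this set stands, namely at the limit of > 50000 nM in this assay, at which 3 of the 3 values shown sit. Within the data shown here, the only step between two measured compounds, a step that the two limits leave unreadable from compound 1 to compound 2, runs from one limit to another and so its size cannot be read. Compound 4 `N#CC1=C(N)Oc2c(N)cc3nc4ccccc4nc3c2C12C(=O)N(Cc1cnnn1-c1c(F)cccc1F)c1ccccc12` differs from compound 3 in one place: 2,6-difluorophenyl in place of 3-bromophenyl on an aromatic nitrogen. No measured step in this set involves the 2,6-difluorophenyl group or the 3-bromophenyl group, so nothing shown speaks for a shift in either direction, and with all three measured values sitting at the limit there is no foothold for a change beyond the scatter. The step expected here is a number no higher from compound 3 to compound 4 (the limit leaves the size open), that is, none that can be read. Compound 4 is estimated to give 50000 nM in this assay, with a range from 20000 nM to 120000 nM, most likely reported only as a limit.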

Compound 4, half-maximal inhibitory concentration: > 50000 nM
Compound 4: a limit, no number; the forecaster's own chance of this, stated with the estimate: 80%; the middle value sits exactly at the limit.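

The step between compound 3 and compound 4 cannot be read, as both values are limits of the assay and not numbers: the limit of > 50000 nM in this assay, at which 4 of the 4 values shown sit.
Whether 2,6-difluorophenyl in place of 3-bromophenyl, or any other exchange shown, changes the activity in this assay stays open.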